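Moving a Fluorine Around a Benzyl Group

The source may report more compounds than this note shows. Statements on the series, on what has been measured and on what is new or still open speak of the compounds shown alone.

Compound 1 `CCN(Cc1ccc(F)cc1)C(=O)C1CCN(S(=O)(=O)c2ccc3cn[nH]c3c2)CC1`: 55%
Compound 2 `CCN(Cc1cccc(F)c1)C(=O)C1CCN(S(=O)(=O)c2ccc3cn[nH]c3c2)CC1`: 89%

Of the compounds shown here, two with a shared core have been measured. In a functional assay on CHO cells for positive allosteric modulation of muscarinic acetylcholine receptor M5 (Homo sapiens), read by calcium flux (a lower number here means a smaller maximal response, a higher number a larger maximal response), compound 1 gives 55%, while compound 2 gives 89%. Compound 2 stands highest of the two numbers, and its nearest neighbour is compound 1. Among the measured compounds shown here, the single measured step, a number 34 percentage points higher from compound 1 to compound 2 (beyond the scatter), is large and beyond the scatter.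

Compound 3 `CCN(Cc1ccccc1F)C(=O)C1CCN(S(=O)(=O)c2ccc3cn[nH]c3c2)CC1` has not been measured. Its difference from compound 2 is 2-fluorophenyl in place of 3-fluorophenyl on a saturated chain carbon bound to an amide-type nitrogen. For the measured compounds named here, the one step that bears on this change shows that moving the fluorine on this phenyl group can shift the maximal response strongly, yet gives no clue about the direction for the 2-fluorophenyl. Compound 3 is therefore expected to lie somewhere between the two measured values, at about 68%, within a wide range from 38% to 98%. That estimate corresponds to an expected step of a number 21 percentage points lower from compound 2 to compound 3 (beyond the scatter), a decrease of uncertain size.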

Compound 3, largest response reached (reported as percent of maximum), in percent of the reference or control that the assay uses: 84%
For compound 3 the middle estimate is 16 percentage points below the measured one; the measured number falls inside the stated range.
By their numbers in this assay, from the lowest: compound 1; then compounds 3 and 2 (each within the scatter of the next).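

The change from 3-fluorophenyl to 2-fluorophenyl on a saturated chain carbon bound to an amide-type nitrogen gives a number 5 percentage points lower from compound 2 to compound 3 (within the scatter) in this assay and so cannot be told apart from no change at all. The change from 4-fluorophenyl to 2-fluorophenyl gives a number 29 percentage points higher from compound 1 to compound 3 (beyond the scatter) and shows that, among these three compounds, only the 4-fluorophenyl of compound 1 stands apart, with the smaller maximal response. No evidence is available that explains this dependence on where the fluorine sits.

From the compounds shown here alone, it remains open how a phenyl group without fluorine would compare, or one carrying a chlorine or a methoxy group instead. Also open, going by these compounds, is what a second fluorine on the same ring would do.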